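This account rests on a few compounds, and the source may have more. Where it says the series, first, only, none or still open, it means among the compounds named here.

In an assay on HEK293 cells for inhibition of transient receptor potential cation channel subfamily M member 8 (Homo sapiens), read by FLIPR, with stated times of 5 min and 3 min (on this read-out higher numbers stand for weaker inhibition and lower numbers for stronger inhibition), compound 1 `O=C(c1sc(-c2cccc(F)c2)nc1O)N1CCOC1` gives 5500 nM. Compound 2 `CCn1nnc(-c2sc(-c3cccc(N(C)C)c3)nc2O)n1` gives 4770 nM in this assay, and the two numbers sit within the scatter of each other, so no order between them can be read from the data. Compound 3 `O=C(c1sc(-c2cccc(F)c2)nc1O)N1CCCOC1` differs from compound 1 by a group of 6 heavy atoms (4 carbon, 1 nitrogen, 1 oxygen; one six-membered non-aromatic ring with 2 hetero atoms) in place of a group of 5 heavy atoms (3 carbon, 1 nitrogen, 1 oxygen; one five-membered non-aromatic ring with 2 hetero atoms), on a carbonyl carbon. Among the measured compounds shown here, no measured pair shows this change, so its effect in this assay is not known from these compounds; the expected step is a 1.1-fold lower number from compound 1 to compound 3 (0.04 log units; within the scatter), none beyond the scatter in either direction. Compound 3 is therefore estimated at 5000 nM, with a range from 1800 nM to 14000 nM.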

Compound 3, half-maximal inhibitory concentration: > 100000 nM
Compound 3 was reported as a limit (the forecaster's own chance of this, stated with the estimate: 10%); middle value at least 20-fold (1.30 log units) away from the limit.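

On the carbonyl carbon, the six-membered non-aromatic ring with 2 hetero atoms in place of the five-membered one gives an at least 18-fold higher number from compound 1 to compound 3 (1.25 log units; beyond the scatter) in this assay. Among the compounds shown here, this is the first sign that activity depends on this position, since one added ring atom here is enough for a large loss. The value of compound 3 is a limit, not a number: the limit of > 100000 nM in this assay, at which 1 of the 3 values shown sits.

Going by these compounds, how far compound 3 lies past that limit remains unknown. Also open, on these data alone, is whether the loss follows ring size or the ring oxygen, which a pyrrolidine or morpholine amide on the same carbonyl carbon would help separate.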